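Series notes: chain extension on the shared core

The source may report more compounds than this note shows. Statements on the series, on what has been measured and on what is new or still open speak of the compounds shown alone.

Measured so far in an assay on HEK293 cells for inhibition of Voltage-dependent T-type calcium channel subunit alpha-1G (Homo sapiens), read by fluorescence, tested at 10 uM; a higher number here means more inhibition at the concentration tested (going by the name of the read-out), a lower number less inhibition:
compound 1, `Cc1nc(-c2ccccc2)c(CNCCN2CCN(C(c3ccccc3)c3ccccc3)CC2)o1`: 57.3%
compound 2, `CCCc1nc(-c2ccccc2)c(CNCCN2CCN(c3ccc(F)cc3)CC2)o1`: 54.1%
compound 3, `CCCc1nc(-c2ccccc2)c(CNCCN2CCN(c3cccc(OC)c3)CC2)o1`: 40.2%

Compound 1 stands highest of the three numbers in this assay; compound 2 comes within the scatter of it, while compound 3 sits beyond the scatter. Among the measured compounds shown here, the only step between compounds that differ in a single place is a number 13.9 percentage points lower from compound 2 to compound 3 (beyond the scatter), and it concerns the group on the amine nitrogen in a ring, not the chain on the core.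

Compound 4 `CCCc1nc(-c2ccccc2)c(CNCCN2CCN(C(c3ccccc3)c3ccccc3)CC2)o1` differs from compound 1 by ethyl in place of hydrogen on a saturated chain carbon bound to an aromatic carbon; cut one bond further out, the same difference reads methyl to propyl. For the measured compounds named here, no measured pair isolates this change. Compounds 2 and 3 both carry the propyl and compound 1 the methyl, but the three also differ at the amine nitrogen in a ring, so the two variations cannot be pulled apart from the numbers at hand. What can be said is that compound 2, with the propyl, lies within the scatter of compound 1 in this assay.

On that basis no step beyond the scatter is expected; the anticipated step is a number 2.3 percentage points lower from compound 1 to compound 4 (within the scatter). Compound 4 is therefore estimated at 55%, with an expected range from 40% to 70%.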

Compound 4, a percentage reported as inhibition, at one concentration (the size of the read-out at that concentration, not a potency): 71.9%
Compound 4: middle estimate off by 16.9 percentage points, on the low side; measured number above the stated range.
By their numbers in this assay, from the lowest: compound 3; then compounds 2 and 1 (each within the scatter of the next); then compound 4.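

In this assay, among the compounds shown here, the pair of compound 1 and compound 4 is the first to isolate the chain on the shared core: ethyl in place of hydrogen on a saturated chain carbon bound to an aromatic carbon, which also reads as methyl to propyl, gives a number 14.6 percentage points higher from compound 1 to compound 4 (beyond the scatter) with nothing else altered. For the compounds shown here, this position therefore matters in its own right for the read-out, at least with the diphenylmethyl group held on the amine nitrogen in a ring, whereas the earlier compounds left its contribution tangled with changes at that nitrogen. The step stands as an observation only, with no accompanying measurement that bears on it.

As far as these compounds go, whether methyl to propyl gives a similar step with the 4-fluorophenyl of compound 2 or the 3-methoxyphenyl of compound 3 on that nitrogen remains open. Also open, from the compounds shown here alone, is how the number runs at this position with a longer chain such as pentyl, a branched chain such as isopropyl, or a ring such as cyclopropyl.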